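Fluoro in place of acetamido: notes on the series

The source may hold more compounds than are shown below. What is called first, only, known or untested is meant among the compounds shown, and "the series" means these compounds.

Values in a functional assay on the whole organism (Gastrocnemius, strain Sprague-Dawley) for inhibition, with Rattus norvegicus as the target; a higher number here means that more compound is needed for the effect, a lower number that less compound is needed:
- compound 1 `O=C1NC(=O)N(/N=C/c2ccc(-c3ccc(Cl)c(Cl)c3)o2)C1O`: 0.019 umol/kg
- compound 2 `CC(=O)Nc1ccc(-c2ccc(/C=N/N3C(=O)NC(=O)C3O)o2)cc1`: > 0.107 umol/kg
- compound 3 `O=C1CN(/N=C/c2ccc(-c3cccc(C(F)(F)F)c3)o2)C(=O)N1`: 0.05 umol/kg

Compound 2 reads > 0.107 umol/kg, and this is a limit of the assay, not a number. Compound 4 `O=C1NC(=O)N(/N=C/c2ccc(-c3ccc(F)cc3)o2)C1O` keeps the core of compound 2 and carries fluoro in place of acetamido on an aromatic carbon, para to a large group (fluoro in place of acetamido on an aromatic carbon). Among the measured compounds shown here, no measured step isolates this change. Compound 1 has the same core, also bears halogen on that ring, and gives 0.019 umol/kg. On that basis, a move to a lower number beyond the scatter is expected, meaning less compound needed. The estimated step is an at least 2.6-fold lower number from compound 2 to compound 4 (0.42 log units; beyond the scatter). For compound 4 the expected value is 0.04 umol/kg, with an estimated range of 0.012 umol/kg to 0.13 umol/kg.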

Compound 4, dose for half-maximal effect: 0.091 umol/kg
The estimate for compound 4 lay 2.3-fold (0.36 log units) below the measured number; measured number inside the range.
By their numbers in this assay, from the lowest: compound 1; then compounds 3 and 4 (each within the scatter of the next). At a limit, above all of these: compound 2.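

Fluoro in place of acetamido on this aromatic carbon, para to a large group, gives a number on the shared core where acetamido gives only a limit: in this assay the change reads as an at least 1.1-fold lower number from compound 2 to compound 4 (0.07 log units; that floor lies within the scatter). Compound 2 stands at a limit of the assay, not at a number: the limit of > 0.107 umol/kg in this assay, at which 1 of the 4 values shown sits.

The change is therefore not shown to lower the number beyond the scatter, and its true size cannot be read. As far as these compounds go, whether an amine or a carboxylic acid at this position would give a number close to that of compound 4 stays open.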